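Alkyl for aryl on the ring nitrogen: compound 4

The source may hold more compounds than are shown below. What is called first, only, known or untested is meant among the compounds shown, and "the series" means these compounds.

Compound 1, `CC(C)c1onc(-c2c(Cl)cccc2Cl)c1COc1ccc(-c2nc3ccc(C(=O)O)cc3n2-c2ccc(F)cc2)cc1`, is the reference point of this set. In an assay on HEK-293T cells for antagonist activity at vitamin D3 receptor (Homo sapiens), read by a luciferase reporter, with a stated time of 24 h (a lower number here means a stronger inhibitor, a higher number a weaker inhibitor), compound 1 gives 2410 nM, the lowest of the two numbers shown. Compound 3, `CC(C)c1onc(-c2c(Cl)cccc2Cl)c1COc1ccc(-c2nc3ccc(C(=O)O)cc3n2C)c(Cl)c1`, in this assay gives 3520 nM, a value that lies within the scatter of compound 1, so no order between the two can be claimed. Compound 2, `CC(=O)C1CCC(Cn2c(-c3ccc(OCc4c(-c5c(Cl)cccc5Cl)noc4C(C)C)cc3)nc3ccc(C(=O)O)cc32)CC1`, is reported in this assay only as a limit, > 10000 nM. Going by the values given here, the move to compound 2 is the one measured step that matters here: an at least 4.1-fold higher number from compound 1 to compound 2 (0.61 log units; beyond the scatter), and the evidence behind it is the limit itself, (the limit of > 10000 nM in this assay, at which 1 of the 3 values shown sits).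

Compound 4, `CC(C)c1onc(-c2c(Cl)cccc2Cl)c1COc1ccc(-c2nc3ccc(C(=O)O)cc3n2CC2CCCCC2)cc1`, is the untested member. Relative to compound 1 the change is cyclohexylmethyl in place of 4-fluorophenyl on an aromatic nitrogen. Among the compounds with values here, this is the same kind of replacement as the one leading to compound 2, lacking only the acetyl group. Because an at least 4.1-fold higher number from compound 1 to compound 2 (0.61 log units; beyond the scatter) was recorded for that closely related change, a weaker number is expected for compound 4, with a fair chance that only a limit is reported. The expected step is a 3.7-fold higher number from compound 1 to compound 4 (0.57 log units; beyond the scatter). Compound 4 is estimated at 9000 nM, with a range from 3000 nM to 30000 nM.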

Compound 4, half-maximal inhibitory concentration: 346 nM
Compound 4: middle estimate off by 26-fold (1.42 log units), on the high side; the measured number lies below the stated range.
By their numbers in this assay, from the lowest: compound 4; then compounds 1 and 3 (each within the scatter of the next). At a limit, above all of these: compound 2.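

On the aromatic nitrogen, cyclohexylmethyl in place of 4-fluorophenyl gives a 7.0-fold lower number from compound 1 to compound 4 (0.84 log units; beyond the scatter) in this assay, so a saturated group at this position is compatible with a lower number than the aryl group of compound 1. Compound 2 alone could not show this, and its weak result now tracks the acetyl group on the saturated ring rather than the swap of aryl for alkyl. Hydrogen in place of that acetyl gives an at least 28-fold lower number from compound 2 to compound 4 (1.46 log units; beyond the scatter), a step whose size is only a bound, as compound 2 is reported as a limit: the limit of > 10000 nM in this assay, at which 1 of the 4 values shown sits.

From the compounds shown here alone, whether a hydroxyl, an amine or a carboxylic acid on that saturated ring carbon would behave like acetyl remains open. Also open, going by these compounds, is whether cyclohexyl directly on the nitrogen, or a longer chain carrying the ring, would hold the number of compound 4.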